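Replacing pentyloxy with methylamino: a cytotoxicity estimate

A few compounds are considered here, and "the series" means these few. Any claim that something is new, unique, unknown or untested is made for them only; others in the source may bear on it.

Of the compounds shown here, three sharing one core have been tested in an ADME assay on HFF cells (Homo sapiens) for cytotoxicity, with a stated time of 8 days; on this read-out higher numbers stand for lower toxicity in this test and lower numbers for higher toxicity in this test. Compound 1 `CCCOc1nc(N)nc2c1ncn2/C=C1/CC1(CO)CO` carries a propoxy group; in this assay compound 1 gives > 300000 nM, which is a limit of the test rather than a number. Compound 3 `CSc1nc(N)nc2c1ncn2/C=C1/CC1(CO)CO` carries methylsulfanyl in the same place; in this assay compound 3 also reaches > 300000 nM, again a limit. For the measured compounds named here, compound 2 `CCCCCOc1nc(N)nc2c1ncn2/C=C1/CC1(CO)CO`, with pentyloxy, is the only one with a true number, giving 259000 nM in this assay. The other two measurements are limits of the test rather than numbers, as the limit of > 300000 nM in this assay, at which 2 of the 3 values shown sit, records.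

The compound still to be tested is compound 4 `CNc1nc(N)nc2c1ncn2/C=C1/CC1(CO)CO`. It differs from compound 2 as follows: methylamino in place of pentyloxy on an aromatic carbon.

Two measured steps inform the expectation. Lengthening the chain gave an at least 1.1-fold lower number from compound 1 to compound 2 (0.06 log units; that floor lies within the scatter), and swapping pentyloxy for methylsulfanyl gave an at least 1.1-fold higher number from compound 2 to compound 3 (0.06 log units; that floor lies within the scatter). Both are tiny and lie within the scatter, so no effect beyond the scatter is expected from exchanging pentyloxy for another group; compound 4 is expected to behave like compound 1 and compound 3, at or beyond the limit. The expected change is a 1.2-fold higher number from compound 2 to compound 4 (0.06 log units; within the scatter). For compound 4 the estimated value in this assay is 300000 nM, ranging from 150000 nM to 600000 nM, with a limit read-out considered likely.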

Compound 4, half-maximal cytotoxic concentration: 265000 nM
Beside the measured number, compound 4's estimate is 1.1-fold (0.05 log units) above it; low and high end bracket the measured number.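

Exchanging pentyloxy for methylamino at this aromatic carbon puts a nitrogen where the oxygen stood and leaves a far shorter group, yet in this assay it gives a 1.0-fold higher number from compound 2 to compound 4 (0.01 log units; within the scatter). This is the first nitrogen-linked group shown at this position, and it gives a true number rather than a limit, so a short group here does not by itself carry a compound to the limit of the test. The comparisons with the other two compounds, an at least 1.1-fold lower number from compound 3 to compound 4 (0.05 log units; that floor lies within the scatter) and an at least 1.1-fold lower number from compound 1 to compound 4 (0.05 log units; that floor lies within the scatter), are less exact, and those two steps are floors rather than sizes because compound 1 and compound 3 each stand at a limit of the test: the limit of > 300000 nM in this assay, at which 2 of the 4 values shown sit.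

The compounds shown leave open whether any group at this aromatic carbon can move the read-out beyond the scatter, since every readable step here stays within it. As far as these compounds go, how a dimethylamino group, a cyclopropylamino group or a longer chain on the nitrogen, such as pentylamino, would read in this assay also remains open.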